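The compounds below may be only part of what the source reports. "The series", "measured", "known", "first", "only" and "open" are said of these compounds alone.

Compound 1 `Cc1cc(C)cc(S(=O)(=O)c2c(C(=O)NCc3cc(O)ncn3)[nH]c3ccc(Cl)cc23)c1`: > 53000 nM
Compound 2 `Cc1cc(C)cc(S(=O)(=O)c2c(C(=O)NCc3ccc(O)c(O)c3)[nH]c3ccc(Cl)cc23)c1`: 18300 nM

Among the measured compounds shown here, in an ADME assay on MT4 cells (Homo sapiens) for cytotoxicity, read by MTT assay (on this read-out higher numbers stand for lower toxicity in this test and lower numbers for higher toxicity in this test), compound 2 gives 18300 nM, the only exact number so far. The > 53000 nM of compound 1 is a limit of the assay. Compound 3 `Cc1cc(C)cc(S(=O)(=O)c2c(C(=O)NCC(=O)NCc3ccccc3O)[nH]c3ccc(Cl)cc23)c1` has (2-hydroxybenzyl)carbamoyl in place of 3,4-dihydroxyphenyl on a saturated chain carbon bound to an amide-type nitrogen. For the measured compounds named here, the one measured step at this place, an at least 2.8-fold lower number from compound 1 to compound 2 (0.46 log units; beyond the scatter), involved a different group, yet it shows that a swap here can shift this assay modestly. With so little evidence, the expected change is small, with no clear move beyond the scatter: a 1.2-fold higher number from compound 2 to compound 3 (0.08 log units; within the scatter). For compound 3, the estimated value is 22000 nM, with an expected range of 7000 nM to 60000 nM.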

Compound 3, half-maximal cytotoxic concentration: > 47300 nM
Compound 3 was reported as a limit; the forecaster's own chance of this, stated with the estimate: 35%; at least 2.1-fold (0.33 log units) between middle value and limit.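

In this assay the swap to (2-hydroxybenzyl)carbamoyl gives an at least 2.5-fold higher number from compound 2 to compound 3 (0.41 log units; beyond the scatter) and so shows that a change at this place can move the number up as well as down. Compound 3 is reported only as a limit: the limit of > 47300 nM in this assay, at which 1 of the 3 values shown sits. Compound 1 and compound 3 both carry limits, and the step between them cannot be read.

Going by these compounds, how high the true number of compound 3 lies stays open, as does which part of the larger group goes with the shift. A carboxylic acid or an amine at this place remains an open case.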